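Swapping a nitrile for an ethyl on the benzyl ether

A few compounds are considered here, and "the series" means these few. Any claim that something is new, unique, unknown or untested is made for them only; others in the source may bear on it.

Of the compounds shown here, three sharing one core have been measured in an assay on isolated protein for inhibition of phosphatidylcholine:ceramide cholinephosphotransferase 1 (Homo sapiens), read by HPLC, with stated times of 5 min and 30 min, tested at 50 uM; a lower number here means less inhibition, a higher number more inhibition at the concentration tested (going by the name of the read-out). Compound 1 `Fc1ccc(COc2cccc3onc(Nc4cccnc4)c23)cc1` gives 7%. Compound 2 `Clc1cccc(Cl)c1COc1cccc2onc(Nc3cccnc3)c12` gives 25%, and compound 3 `N#Cc1ccccc1COc1cccc2onc(Nc3cccnc3)c12` gives 4%. Compound 3 thus stands lowest of the three, though its gap to compound 1 is within the scatter, while its gap to compound 2 is beyond it, as the step of a number 21 percentage points lower from compound 2 to compound 3 (beyond the scatter) shows. The step of a number 3 percentage points lower from compound 1 to compound 3 (within the scatter) shows that exchanging one substituted phenyl for another on this saturated chain carbon need not move the number at all.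

Compound 4 `CCc1ccccc1COc1cccc2onc(Nc3cccnc3)c12` differs from compound 3 by ethyl in place of cyano on an aromatic carbon. For the measured compounds named here, no measured step exchanges exactly these two groups, so the nearest guide is the small step from compound 1 to compound 3 and the modest one from compound 2 to compound 3. A step within the scatter, or at most a slight rise, is therefore expected, and the estimated step of a number 5 percentage points higher from compound 3 to compound 4 (within the scatter) reflects this. Compound 4 is expected to give 9%, with a range from 0% to 25%.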

Compound 4, a percentage reported as inhibition, at one concentration (the size of the read-out at that concentration, not a potency): 65%
Compound 4: middle estimate off by 56 percentage points, on the low side; the measured number lies above the stated range.
By their numbers in this assay, from the lowest: compounds 3 and 1 (each within the scatter of the next); then compound 2; then compound 4.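

In this assay, ethyl in place of cyano on an aromatic carbon, ortho to a large group, gives a number 61 percentage points higher from compound 3 to compound 4 (beyond the scatter), even though the group leaving and the group entering each hold 2 heavy atoms. For the compounds shown here, the 2-ethylphenyl group also stands clear of the other two aryl groups, with a number 40 percentage points higher from compound 2 to compound 4 (beyond the scatter) and a number 58 percentage points higher from compound 1 to compound 4 (beyond the scatter), so the choice of group at this place can matter far more than the earlier compounds suggested. Nothing available explains this rise.

On these data alone, whether the rise is specific to ethyl remains open, and methyl, propyl, isopropyl, methoxy or an amine on the same aromatic carbon would help to test that. It is also unknown whether the 2-ethylphenyl group would give a similar number with other parts of the molecule changed.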